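Swapping a pyrazole for a carboxylic acid in a stability series

A few compounds are considered here, and "the series" means these few. Any claim that something is new, unique, unknown or untested is made for them only; others in the source may bear on it.

Three compounds built on one shared core have been examined in an in vitro ADME assay on microsomes from liver (Homo sapiens) for metabolic stability; on this read-out lower numbers stand for a shorter-lived compound and higher numbers for a longer-lived compound. Compound 1, `COc1ccc(-c2cc(-c3ccc(S(=O)(=O)NC4CC4)cc3)cnc2N)cn1`, gives 1.9 h. Compound 2, `COc1ccc(-c2cc(-c3ccc(NS(C)(=O)=O)cc3)cnc2N)cn1`, reaches the ceiling of the assay: its result of > 4.16 h is a limit rather than a number. Compound 3, `COc1ccc(-c2cc(-c3ccc(-n4cccn4)cc3)cnc2N)cn1`, gives 3.38 h. Where compound 3 stands is modest: its number and that of compound 1 sit within the scatter of each other, the step being a 1.8-fold higher number from compound 1 to compound 3 (0.25 log units; within the scatter), so neither can be ranked above the other. The third value, that of compound 2, is a limit. The step of an at least 2.1-fold higher number from compound 1 to compound 2 (0.34 log units; beyond the scatter) is the only one beyond the scatter, while an at least 1.2-fold lower number from compound 2 to compound 3 (0.09 log units; that floor lies within the scatter) stays within it.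

Compound 4, `COc1ccc(-c2cc(-c3ccc(C(=O)O)cc3)cnc2N)cn1`, differs from compound 3 in one place: carboxy in place of 1H-pyrazol-1-yl on an aromatic carbon. Among the compounds with values here, none of the measured steps involves a carboxy group, so they bear on this change only loosely. Within the data shown here, the one step beyond the scatter, an at least 2.1-fold higher number from compound 1 to compound 2 (0.34 log units; beyond the scatter), shows that changing the group at this position can raise the number; the other two changes stayed within the scatter. The expectation for compound 4 is therefore a small rise or none beyond the scatter, a 1.2-fold higher number from compound 3 to compound 4 (0.07 log units; within the scatter). Compound 4 is estimated at 4 h, within a range from 2.4 h to 7 h.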

Compound 4, half-life: > 4.16 h
Compound 4: no number, only a limit (the forecaster's own chance of this, stated with the estimate: 45%); at least 1.0-fold (0.01 log units) between middle value and limit.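

Compound 4 adds a second group on this aromatic carbon that clears compound 1 in this assay: an at least 2.1-fold higher number from compound 1 to compound 4 (0.34 log units; beyond the scatter), so carboxy now stands with methanesulfonamido, while 1H-pyrazol-1-yl, in compound 3, goes against that pattern with a step from compound 1 that stays within the scatter. The change from the ring to carboxy is less clear, with an at least 1.2-fold higher number from compound 3 to compound 4 (0.09 log units; that floor lies within the scatter), so this floor does not establish that compound 4 lasts longer than compound 3. Compound 2 and compound 4 cannot be ranked and the step between them cannot be read, because both results are limits rather than numbers: the limit of > 4.16 h in this assay, at which 2 of the 4 values shown sit.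

Going by these compounds, how far compound 2 and compound 4 lie past that limit remains open, and so does any order between them. Also open, on these data alone, is whether the carboxylic acid itself matters at this position, which a close relative such as a primary amide or a methyl ester on the same aromatic carbon would help to test.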